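Epimer of a weak methoxy analogue in the enone series

The compounds below may be only part of what the source reports. "The series", "measured", "known", "first", "only" and "open" are said of these compounds alone.

Two members of the series carry a measured number. Compound 1 `CCCCCCCCCCO[C@H]1C=C(COC(C)=O)C(=O)[C@H](O)[C@H]1O` is the decyloxy member; in an assay on isolated protein for inhibition of glutathione S-transferase P (Homo sapiens), read by spectrophotometry, with a stated time of 3 min (a lower number here means a stronger inhibitor, a higher number a weaker inhibitor), compound 1 gives 25300 nM. Compound 2 `CO[C@H]1C=C(COC(C)=O)C(=O)[C@H](O)[C@H]1O` carries a methoxy group in place of the decyloxy chain. In this assay compound 2 gives only the upper limit of the measurement, > 100000 nM, a limit rather than a number, so compound 2 can only be placed at or beyond the weak end of what the method reports; the point at which it sits is the limit of > 100000 nM in this assay, at which 1 of the 2 values shown sits.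

Compound 3 `CO[C@@H]1C=C(COC(C)=O)C(=O)[C@H](O)[C@H]1O` is the next member to be measured. Compared with compound 2 the change is the two compounds have the same atoms and bonds and differ only in configuration as drawn: 1 of 3 stereo elements differ; a stereocentre at a saturated ring carbon is drawn S in compound 2 and R in compound 3: the two compounds have the same atoms and bonds and differ only in configuration as drawn, one of three stereo elements differing, a stereocentre at a saturated ring carbon drawn S in compound 2 and R in compound 3.

Going by the values given here, no step between measured compounds is available. With compound 2 already at the limit, the step that the limit leaves unreadable from compound 2 to compound 3 is expected to stay within the scatter, in no clear direction. Compound 3 is therefore estimated at 120000 nM in this assay, within a range from 30000 nM to 400000 nM, with a fair chance that only a limit is returned again.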

Compound 3, half-maximal inhibitory concentration: > 100000 nM
Compound 3: only a limit was reported (the forecaster's own chance of this, stated with the estimate: 70%); the middle value does not contradict the limit.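

Going by these compounds alone, compound 2 and compound 3 both return only a limit in this assay, and no step between the two can be read. The compounds shown leave open whether the configuration drawn at the saturated ring carbon changes inhibition in this assay at all, and how far past the limit either compound lies.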